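The source may report more compounds than this note shows. Statements on the series, on what has been measured and on what is new or still open speak of the compounds shown alone.

Working notes on the series. The shared core is the same in all four compounds; what changes is the group on one aromatic carbon and the length of its chain. Compound 1 is `CCCCCCCCSc1nc(N)nc2c1ncn2/C=C1/CC1(CO)CO`, compound 2 is `CCCCCCSc1nc(N)nc2c1ncn2/C=C1/CC1(CO)CO`, compound 3 is `CCCCCCOc1nc(N)nc2c1ncn2/C=C1/CC1(CO)CO`, and the still unmeasured compound 4 is `CCCCOc1nc(N)nc2c1ncn2/C=C1/CC1(CO)CO`.

In an ADME assay on HFF cells (Homo sapiens) for cytotoxicity, with a stated time of 8 days (a lower number here means that less compound is tolerated, a higher number that more compound is tolerated), compound 1 gives > 300000 nM, which is a limit of the assay and not a number. Compound 2 gives > 300000 nM in this assay, again a limit. Compound 3 gives > 200000 nM in this assay, also a limit.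

The change from compound 1 to compound 2 is hydrogen in place of ethyl on a saturated chain carbon, six bonds along the chain from a sulfur, and in this assay it made a step that the two limits leave unreadable from compound 1 to compound 2. The same kind of change leads from compound 3 to compound 4: hydrogen in place of ethyl on a saturated chain carbon, four bonds along the chain from an oxygen on an aromatic ring. The two places are not identical: in the first pair the carbon sits six bonds along the chain from a sulfur, in the second four bonds along the chain from an oxygen on an aromatic ring. The cores of compound 1 and compound 3 differ by hexyloxy in place of octylsulfanyl on an aromatic carbon; the steps a step that the two limits leave unreadable from compound 1 to compound 3 and a step that the two limits leave unreadable from compound 2 to compound 3 are equally unreadable.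

Because the limit of > 200000 nM in this assay, at which 1 of the 3 values shown sits, and the limit of > 300000 nM in this assay, at which 2 of the 3 values shown sit, hold every measured value of the series at the top of the tested range, compound 4 is expected to do the same, with a step that the limit leaves unreadable from compound 3 to compound 4 as the expected step. Compound 4 is therefore estimated at 300000 nM, most likely reported once more as a limit, with 150000 nM to 1000000 nM as the expected range.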

Compound 4, half-maximal cytotoxic concentration: > 300000 nM
Compound 4 ended at the assay's limit; the forecaster's own chance of this, stated with the estimate: 85%; the middle value sits exactly at the limit.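

In this assay compound 4 gives > 300000 nM, a limit of the assay and not a number. Among the compounds shown here, no step from compound 1, compound 2 or compound 3 to compound 4 can be read, as all four values are limits. The compounds shown leave open where the half-maximal cytotoxic concentration of any of them lies, and whether chain length or hexyloxy in place of hexylsulfanyl makes any difference in this assay.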